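Swapping the aromatic substituent in a guanidine series

The compounds below may be only part of what the source reports. "The series", "measured", "known", "first", "only" and "open" are said of these compounds alone.

Measured compounds:
compound 1 `Cc1nc(N)sc1CCCN/C(N)=N/C(=O)NC(C)c1ccc(OC(F)(F)F)cc1`: 724 nM
compound 2 `Cc1ccc(C(C)NC(=O)/N=C(\N)NCCCc2sc(N)nc2C)cc1`: 22.4 nM
compound 3 `CCC(NC(=O)/N=C(\N)NCCCc1sc(N)nc1C)c1ccccc1`: 10.7 nM

In a functional assay on Right cardiac atrium for agonist activity at histamine H2 receptor (Cavia porcellus), with a stated time of 30 min, in the presence of a further agent that is not named here (on this read-out higher numbers stand for an effect only at larger amounts of compound and lower numbers for an effect already at smaller amounts), compound 2 stands second highest of the three numbers; compound 3 gives a somewhat lower value, while compound 1 gives a far higher one. Within the data shown here, the only step measured in one place is a 32-fold lower number from compound 1 to compound 2 (1.51 log units; beyond the scatter). Compound 4 `Cc1nc(N)sc1CCCN/C(N)=N/C(=O)NC(C)c1ccccc1F` differs from compound 2 by 2-fluorophenyl in place of 4-methylphenyl on a saturated chain carbon bound to an amide-type nitrogen and a saturated chain carbon. Among the measured compounds shown here, no measured step covers this change; the step from compound 1 to compound 2 concerns a different group, so it offers no direct guide. Compound 2 and compound 3 carry aromatic rings without fluorine and both give low values, so no shift beyond the scatter is expected, a 1.1-fold lower number from compound 2 to compound 4 (0.05 log units; within the scatter). Compound 4 is estimated at 20 nM, within 7 nM to 60 nM.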

Compound 4, half-maximal effective concentration: 12.3 nM
Beside the measured number, compound 4's estimate is 1.6-fold (0.21 log units) above it, and the stated range covers the measured number.
By their numbers in this assay, from the lowest: compounds 3, 4 and 2 (each within the scatter of the next, the first and the last beyond it); then compound 1.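

Placing 2-fluorophenyl in place of 4-methylphenyl on this saturated chain carbon gives a 1.8-fold lower number from compound 2 to compound 4 (0.26 log units; within the scatter) in this assay. The large step seen earlier is therefore not what every change to this aromatic group brings, and a ring carrying fluorine can sit here with the number held within the scatter. Nothing available explains this result.

Going by these compounds, this step changes both the ring substituent and its place on the ring, so the contribution of each stays open. On these data alone, how a ring carrying an amine or a carboxylic acid would behave in this assay also remains open.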